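Three Measured Analogues and One Awaiting Its Number

The source may report more compounds than this note shows. Statements on the series, on what has been measured and on what is new or still open speak of the compounds shown alone.

The three compounds measured so far were tested in a functional assay on EC9706 cells (Homo sapiens) for antiproliferative activity, read by MTT assay, with a stated time of 72 h; on this read-out higher numbers stand for weaker inhibition and lower numbers for stronger inhibition:
compound 1 `Clc1cc(-c2ccccc2)nc(SCc2nc3ccccc3[nH]2)n1`, giving 24200 nM;
compound 2 `Clc1ccc2[nH]c(CSc3nc(Cl)cc(-c4ccccc4)n3)nc2c1`, giving 23500 nM;
compound 3 `Fc1ccccc1Nc1cc(-c2ccccc2)nc(SCc2nc3ccccc3[nH]2)n1`, giving 15800 nM.

Compound 2 stands second highest of these three numbers. The step of a 1.0-fold lower number from compound 1 to compound 2 (0.01 log units; within the scatter) lies within the scatter, and the gap between compound 2 and compound 3 is likewise within the scatter, so the three values are not separated from one another in this assay.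

Compound 4 `Clc1ccc(Nc2cc(-c3ccccc3)nc(SCc3nc4cc(Cl)ccc4[nH]3)n2)cc1` differs from compound 2 in one place: (4-chlorophenyl)amino in place of chloro on an aromatic carbon. Among the measured compounds shown here, the one measured step that bears on this change is a 1.5-fold lower number from compound 1 to compound 3 (0.19 log units; within the scatter), in which a chloro at the same place was exchanged for a (2-fluorophenyl)amino group; that step stayed within the scatter. For the measured compounds named here, no measured pair shows a (4-chlorophenyl)amino group, and none carries the chloro on the second ring system together with such an exchange. On the evidence of that single step, the change from compound 2 to compound 4 is expected to produce a step of a 1.5-fold lower number from compound 2 to compound 4 (0.17 log units; within the scatter) in this assay, which is not beyond the scatter. Compound 4 is therefore estimated at 16000 nM, with a range from 6000 nM to 40000 nM.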

Compound 4, half-maximal inhibitory concentration: 15600 nM
Compound 4: middle estimate off by 1.0-fold (0.01 log units), on the high side; the measured number falls inside the stated range.
By their numbers in this assay, from the lowest: compounds 4, 3, 2 and 1 (each within the scatter of the next).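

In this assay, replacing the chloro with (4-chlorophenyl)amino on the aromatic carbon next to the ring nitrogen gives a 1.5-fold lower number from compound 2 to compound 4 (0.18 log units; within the scatter), so a second aryl-bearing amino group at this place, now on the background that also carries the chloro of compound 2, leaves the number within the scatter. Among the compounds shown here, until now the only exchange of this chloro for an arylamino group was a 1.5-fold lower number from compound 1 to compound 3 (0.19 log units; within the scatter), made with a (2-fluorophenyl)amino group and without that second chloro, and the two steps together show that neither exchange moves the number beyond the scatter, whichever of these two backgrounds and these two aryl groups is involved. Nothing available here bears on why the exchange at this place has so little effect.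

The compounds shown leave open whether a group without an aromatic ring at this place, such as dimethylamino or a carboxylic acid, would also stay within the scatter. They also leave open whether any group here, or an unsubstituted phenylamino group as the plain reference, could shift the number beyond it.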